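This account rests on a few compounds, and the source may have more. Where it says the series, first, only, none or still open, it means among the compounds named here.

Of the compounds shown here, three have so far been measured in an assay for inhibition of Dihydrofolate reductase (Homo sapiens); a lower number here means a less potent compound, a higher number a more potent compound, by a factor of ten per unit of this negative logarithm. Compound 1 `CC1CCc2nc(N)nc(O)c2C1` gives 4.26, and compound 2 `Nc1nc(O)c2c(Cl)cccc2n1` gives 4.66. Compound 3 `Nc1nc(N)c2c(Cl)c(Br)ccc2n1` gives 7, the highest of the three; its lead over compound 2 and over compound 1 lies beyond the usual scatter, so compound 3 is the most potent of the measured set. Compound 4 `Nc1nc(N)c2c(Cl)c(N)ccc2n1` has not yet been measured. It differs from compound 3 in one place: amino in place of bromo on an aromatic carbon. Going by the values given here, no measured pair shows this change, so its effect can only be estimated. The expected step is a number 0.50 log units lower from compound 3 to compound 4 (beyond the scatter), a modest loss beyond the scatter in this assay, because compound 3 reaches 7 and a single change of this kind is expected to give up some of that. Compound 4 is expected to give 6.5, within 5.7 to 7.3.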

Compound 4, logarithm of the reciprocal of the active concentration, log(1/C): 6.18
Compound 4: the middle estimate sits 0.32 log units above what was measured, within the range that was stated.
By their numbers in this assay, from the lowest: compound 1; then compound 2; then compound 4; then compound 3.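

In this assay the exchange of bromo for amino on this aromatic carbon, ortho to a chloro group, gives a number 0.82 log units lower from compound 3 to compound 4 (beyond the scatter) and so counts as a modest loss. This shows that the position is sensitive to the group it carries, since replacing a single bromine atom with a single nitrogen atom moves the number beyond the scatter. Nothing available explains the drop. Going by these compounds, whether a methyl group, a methoxy group or a longer chain at this position would match bromo remains open, and so does the effect of a plain hydrogen there.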